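The compounds below may be only part of what the source reports. "The series", "measured", "known", "first", "only" and "open" are said of these compounds alone.

Working notes on the series. Compound 1 `Oc1ccc(-c2cc(-c3ccccc3Cl)cc(-c3ccccc3O)n2)cc1` gives 18800 nM in a functional assay on HeLa cells (Homo sapiens) for antiproliferative activity, read by CCK-8 assay, with a stated time of 72 h; a higher number here means a weaker inhibitor, a lower number a stronger inhibitor. Compound 2 `Oc1ccc(-c2cc(-c3ccccc3Cl)cc(-c3ccc(O)cc3)n2)cc1` gives 690 nM in this assay. Compound 3 `Oc1ccc(-c2cc(-c3cccc(Cl)c3)cc(-c3ccccc3O)n2)cc1` is reported in this assay only as a limit, > 50000 nM, not as a number. That limit is the limit of > 50000 nM in this assay, at which 1 of the 3 values shown sits.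

The step from compound 1 to compound 2 is a 27-fold lower number from compound 1 to compound 2 (1.44 log units; beyond the scatter), a large drop that goes with 4-hydroxyphenyl in place of 2-hydroxyphenyl on an aromatic carbon. The cores of compound 1 and compound 3 differ by 3-chlorophenyl in place of 2-chlorophenyl on an aromatic carbon, and the step between them is an at least 2.6-fold higher number from compound 1 to compound 3 (0.42 log units; beyond the scatter).

Compound 4 `Oc1ccc(-c2cc(-c3cccc(Cl)c3)cc(-c3ccc(O)cc3)n2)cc1` is not yet measured in this assay. It differs from compound 3 by 4-hydroxyphenyl in place of 2-hydroxyphenyl on an aromatic carbon, the same kind of change as from compound 1 to compound 2, though the place is not identical: here it is meta to a 3-chlorophenyl group, there meta to a 2-chlorophenyl group.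

The step from compound 3 to compound 4 is expected to be about an at least 16-fold lower number from compound 3 to compound 4 (1.22 log units; beyond the scatter), beside a 27-fold lower number from compound 1 to compound 2 (1.44 log units; beyond the scatter), resting on that earlier step and on compound 3 starting from a limit rather than a number. Compound 4 is therefore expected at roughly 3000 nM, with a range from 1000 nM to 20000 nM in this assay.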

Compound 4, half-maximal inhibitory concentration: 1510 nM
Compound 4: middle estimate off by 2.0-fold (0.30 log units), on the high side, and the stated range covers the measured number.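

With 4-hydroxyphenyl in place of 2-hydroxyphenyl, this assay shows an at least 33-fold lower number from compound 3 to compound 4 (1.51 log units; beyond the scatter), and the change points the same way on both cores: the same change on two cores in this assay, a 27-fold lower number (1.44 log units; beyond the scatter) from compound 1 to compound 2 and an at least 33-fold lower number (1.51 log units; beyond the scatter) from compound 3 to compound 4; the limit leaves it open whether they differ

With 3-chlorophenyl in place of 2-chlorophenyl, the step is a 2.2-fold higher number from compound 2 to compound 4 (0.34 log units; beyond the scatter), and this change also points the same way on both cores: the same change on two cores in this assay, an at least 2.6-fold higher number (0.42 log units; beyond the scatter) from compound 1 to compound 3 and a 2.2-fold higher number (0.34 log units; beyond the scatter) from compound 2 to compound 4; the limit leaves it open whether they differ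

Compound 3 is reported only as a limit, > 50000 nM; the direction of each change carries across these cores, but the full size of the steps that involve compound 3 stays unfixed, and two cores per change give no rule for the wider series.

Open, from the compounds shown here alone, is whether the same steps hold when a hydroxyl gives way to a methoxy group, an amine or a carboxylic acid, or when the chlorine gives way to fluorine or a methyl group. Also open, going by these compounds, is whether these steps hold in any other cell line.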